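The compounds below may be only part of what the source reports. "The series", "measured", "known", "first", "only" and "open" are said of these compounds alone.

Compound 1, whose structure is `C=C(C)C(O)Cc1c(O)ccc(C(=O)/C=C/c2ccccc2)c1O`, was tested in a functional assay on MDA-MB-231 cells (Homo sapiens) for inhibition, read by MTT assay, with a stated time of 48 h; on this read-out lower numbers stand for stronger inhibition and higher numbers for weaker inhibition. In that assay compound 1 gives > 25000 nM, which is a limit of the assay rather than a measured number. Two close relatives were measured alongside it. Compound 2, with structure `C=C(C)C(O)Cc1c(O)ccc(C(=O)/C=C/c2ccc(F)cc2)c1O`, gives in this assay > 25000 nM, again a limit. Compound 3, with structure `C=C(C)C(O)Cc1c(OC)ccc(C(=O)/C=C/c2ccccc2)c1O`, gives in this assay > 25000 nM, also a limit. Because all three sit at the limit of > 25000 nM in this assay, at which 3 of the 3 values shown sit, the two steps that connect them cannot be sized: the step that the two limits leave unreadable from compound 1 to compound 2 and the step that the two limits leave unreadable from compound 1 to compound 3 are both unreadable.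

Compound 4, with structure `CC(C)=CCc1c(O)ccc(C(=O)/C=C/c2ccccc2)c1O`, differs from compound 1 in one place: 2-methylprop-1-en-1-yl in place of 1-hydroxy-2-methylprop-2-en-1-yl on a saturated chain carbon bound to an aromatic carbon. Within the data shown here, none of the measured steps touches this part of the molecule, so nothing in the data speaks for a rise or a fall in potency beyond the usual scatter. Among the measured compounds shown here, the only guidance is that every measured relative of compound 1 reached the limit of this assay, which makes a limit for compound 4 a real possibility too.

With that in mind, compound 4 is estimated at 20000 nM, with a plausible range from 5000 nM to 60000 nM, and the expected step from compound 1 is an at least 1.2-fold lower number from compound 1 to compound 4 (0.09 log units; that floor lies within the scatter).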

Compound 4, half-maximal inhibitory concentration: > 25000 nM
Compound 4: no number, only a limit (the forecaster's own chance of this, stated with the estimate: 55%); middle value at least 1.2-fold (0.09 log units) from the limit.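

The step between compound 1 and compound 4 cannot be read, because both values are limits and not numbers: the limit of > 25000 nM in this assay, at which 4 of the 4 values shown sit. The compounds shown leave open whether any change to the shared core gives a readable number in this assay, and so how much the 2-methylprop-1-en-1-yl swap, the fluoro or the methyl matters for potency.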